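Replacing the Methylamino Benzyl Arm with a Carboxyphenoxymethyl Group

A few compounds are considered here, and "the series" means these few. Any claim that something is new, unique, unknown or untested is made for them only; others in the source may bear on it.

Compound 2 `CN(Cc1cccc(C(=O)O)c1)c1ccc(OCc2c(-c3c(Cl)cccc3Cl)noc2C2CC2)nc1C(F)(F)F` gives 102% in an assay on isolated protein for agonist activity at Bile acid receptor (Homo sapiens), read by FRET; a lower number here means a smaller maximal response, a higher number a larger maximal response. This stands level with compound 1 `CC(C)c1onc(-c2c(Cl)cccc2Cl)c1COc1ccc(N(C)Cc2cccc(C(=O)O)c2)c(C(F)(F)F)n1`, which gives 102%; together the two are the lowest of three numbers. Compound 3 `CN(Cc1ccc(C(=O)NCCS(=O)(=O)O)cc1)c1ccc(OCc2c(-c3c(Cl)cccc3Cl)noc2C2CC2)nc1C(F)(F)F` gives 105%, within the scatter of compound 2. Among the measured compounds shown here, the only measured step, no change at the digits printed from compound 1 to compound 2 (within the scatter), concerns a different part of the shared core and does not touch the group altered here. Compound 4 `O=C(O)c1ccccc1OCc1ccc(OCc2c(-c3c(Cl)cccc3Cl)noc2C2CC2)nc1C(F)(F)F` differs from compound 2 by (2-carboxyphenoxy)methyl in place of (3-carboxybenzyl)(methyl)amino on an aromatic carbon. For the measured compounds named here, no measured step bears directly on this change, and all three maximal responses lie close together near a full response. Compound 4 is therefore expected to give about 100%, in the range 85% to 112%. The expected step is a number 2 percentage points lower from compound 2 to compound 4 (within the scatter), which is not expected to exceed the scatter.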

Compound 4, largest response reached (reported as efficacy), in percent of the reference or control that the assay uses: 91%
For compound 4 the middle estimate is 9 percentage points above the measured one; low and high end bracket the measured number.
By their numbers in this assay, from the lowest: compound 4; then compounds 1, 2 and 3 (each within the scatter of the next).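

At this position, on an aromatic carbon ortho to a trifluoromethyl group, the swap to (2-carboxyphenoxy)methyl is the first shown change to move the read-out in this assay beyond the scatter, with a number 11 percentage points lower from compound 2 to compound 4 (beyond the scatter) for this replacement of (3-carboxybenzyl)(methyl)amino. Compound 4 at 91% still keeps most of the maximal response, so the arm can be altered substantially without losing it. Nothing measured here explains the drop. Going by these compounds, the change alters the arm's linkage and the carboxylic acid's place together, so it remains open whether (3-carboxyphenoxy)methyl would match compound 2, and how a tetrazole in place of the carboxylic acid would fare on this arm.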